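Imidazopyrazine series: ortho-fluorophenyl replacing para-chlorophenyl

The source may report more compounds than this note shows. Statements on the series, on what has been measured and on what is new or still open speak of the compounds shown alone.

Three analogues on the shared core have been run in a functional assay on NCI-H522 cells (Homo sapiens) for inhibition, read by sulforhodamine B assay, with a stated time of 48 h, tested at 10 uM; on this read-out higher numbers stand for more inhibition at the one concentration tested (going by the name of the read-out) and lower numbers for less inhibition. Compound 1 `c1cn2cc(-c3ccsc3)nc(-c3ccc4ncn(C5CCCCC5)c4c3)c2n1` gives 10.3%, compound 2 `CC(=O)c1ccc(-c2cn3ccnc3c(-c3ccc4ncn(C5CCCCC5)c4c3)n2)cc1` gives 10.4%, and compound 3 `Clc1ccc(-c2cn3ccnc3c(-c3ccc4ncn(C5CCCCC5)c4c3)n2)cc1` gives 19.8%. The number for compound 3 is the highest of the three, but the differences are small: a number 9.4 percentage points higher from compound 2 to compound 3 (within the scatter) and a number 9.5 percentage points higher from compound 1 to compound 3 (within the scatter), each within the scatter, as is a number 0.1 percentage points higher from compound 1 to compound 2 (within the scatter).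

Compound 4 `Fc1ccccc1-c1cn2ccnc2c(-c2ccc3ncn(C4CCCCC4)c3c2)n1` is not yet measured. Relative to compound 3 the change is 2-fluorophenyl in place of 4-chlorophenyl on an aromatic carbon. Among the compounds with values here, the steps that bear on it are the swaps of the same aryl group: a number 9.4 percentage points higher from compound 2 to compound 3 (within the scatter), a number 9.5 percentage points higher from compound 1 to compound 3 (within the scatter) and a number 0.1 percentage points higher from compound 1 to compound 2 (within the scatter), none of them beyond the scatter. Nothing in this set shows the aryl group moving this read-out in either direction, so no step beyond the scatter is expected for compound 4 in this assay , the expected step being a number 5.8 percentage points lower from compound 3 to compound 4 (within the scatter). Compound 4 is therefore estimated at 14%, within a range of 0% to 32%.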

Compound 4, a percentage reported as inhibition, at one concentration (the size of the read-out at that concentration, not a potency): 17.8%
Compound 4: middle estimate off by 3.8 percentage points, on the low side; the measured number falls inside the stated range.
By their numbers in this assay, from the lowest: compounds 1, 2, 4 and 3 (each within the scatter of the next).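

In this assay, the 2-fluorophenyl group gives a number 2 percentage points lower from compound 3 to compound 4 (within the scatter), a number 7.4 percentage points higher from compound 2 to compound 4 (within the scatter) and a number 7.5 percentage points higher from compound 1 to compound 4 (within the scatter), so all three new steps stay within the scatter. The series now has a phenyl carrying its substituent at a different ring place from the 4-chlorophenyl and 4-acetylphenyl groups, and this aryl position still shows no step beyond the scatter; however, the swap from 4-chlorophenyl changes both the halogen and its place on the phenyl ring, so the two changes cannot be separated. No supporting data bear on this result.

From the compounds shown here alone, it remains open whether 4-fluorophenyl or 2-chlorophenyl would separate those two changes. Going by these compounds, it is also open whether a phenyl carrying an aminomethyl group or a carboxylic acid, or a morpholine in place of the aryl group, would move this read-out beyond the scatter.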